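The compounds below may be only part of what the source reports. "The series", "measured", "known", "first", "only" and "open" are said of these compounds alone.

Measured so far:
compound 1 `O=C(CCN1CCN(c2ccc(Cl)cc2)CC1)c1ccc(Br)cc1`: 52100 nM
compound 2 `O=C(CCN1CCN(c2ccc(Cl)cc2)CC1)c1ccc(F)c(F)c1`: 86200 nM
compound 3 `O=C(CCN1CCN(c2ccc(Cl)cc2)CC1)c1ccc(F)c(Cl)c1`: 114000 nM

In an ADME assay on Vero cells (Chlorocebus sabaeus) for cytotoxicity, read by resazurin assay, with a stated time of 72 h (on this read-out higher numbers stand for weaker inhibition and lower numbers for stronger inhibition), compound 1 gives 52100 nM, the low end of these three numbers, with its nearest neighbour within the scatter and its furthest just beyond it.

Compound 4 `O=C(CCN1CCN(c2ccc(Cl)cc2)CC1)c1ccc(OC(F)(F)F)cc1` has not been measured yet. It keeps the rest of compound 1 and alters a single group: trifluoromethoxy in place of bromo on an aromatic carbon. That is trifluoromethoxy in place of bromo on an aromatic carbon.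

Going by the values given here, no measured compound carries trifluoromethoxy, so the evidence is indirect. The closest guides are the two steps that also replace the 4-bromophenyl on a carbonyl carbon: a 1.7-fold higher number from compound 1 to compound 2 (0.22 log units; within the scatter), and a 2.2-fold higher number from compound 1 to compound 3 (0.34 log units; beyond the scatter). Both point upward, and neither is large.

A similarly small upward move is therefore expected, probably not beyond the scatter. The expected step is a 1.2-fold higher number from compound 1 to compound 4 (0.10 log units; within the scatter). For compound 4 the estimated value is 65000 nM, with an expected range of 32000 nM to 130000 nM.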

Compound 4, half-maximal inhibitory concentration: 95600 nM
Compound 4: middle estimate off by 1.5-fold (0.17 log units), on the low side, within the range that was stated.
By their numbers in this assay, from the lowest: compounds 1, 2, 4 and 3 (each within the scatter of the next, the first and the last beyond it).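

Trifluoromethoxy in place of bromo gives a 1.8-fold higher number from compound 1 to compound 4 (0.26 log units; within the scatter) in this assay, so on this aromatic carbon a group of five heavy atoms with one hydrogen-bond acceptor can replace a single bromine without a step beyond the scatter. Going by these compounds alone, compounds 1, 2 and 3 carry only halogens on this ring, which makes compound 4 the first example here of a group attached through oxygen. No measurement at hand offers a reason for this result.

From the compounds shown here alone, whether an amine or a carboxylic acid on this same carbon would give a step beyond the scatter remains open, as does the outcome for a longer chain there. All four compounds also keep the same core, so they cannot show how much that core contributes to these numbers.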